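The compounds below may be only part of what the source reports. "The series", "measured", "known", "first", "only" and "open" are said of these compounds alone.

Measured so far in an ADME assay on the whole organism for cytotoxicity, with Artemia salina as the target, with a stated time of 24 h; on this read-out higher numbers stand for an effect only at larger amounts of compound and lower numbers for an effect already at smaller amounts:
- compound 1 `Cc1ccc(S(=O)(=O)NC(=O)Nc2ccccc2C(=O)/C=C/c2ccccc2)cc1`: 25 ug/mL
- compound 2 `COc1ccc(/C=C/C(=O)c2ccccc2NC(=O)NS(=O)(=O)c2ccc(C)cc2)cc1OC`: 12.9 ug/mL
- compound 3 `Cc1ccc(S(=O)(=O)NC(=O)Nc2ccccc2C(=O)/C=C/c2cc(O)ccc2[N+](=O)[O-])cc1`: 18.3 ug/mL

Compound 3 stands second highest of the three numbers. All three values sit within the scatter of one another: a 1.9-fold lower number from compound 1 to compound 2 (0.29 log units; within the scatter), a 1.4-fold lower number from compound 1 to compound 3 (0.14 log units; within the scatter), and a 1.4-fold higher number from compound 2 to compound 3 (0.15 log units; within the scatter). No ordering among compound 1, compound 2 and compound 3 can be read from these numbers.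

Compound 4 `Cc1ccc(S(=O)(=O)NC(=O)Nc2ccccc2C(=O)/C=C/c2ccc(F)cc2)cc1` is the next member, differing from compound 3 in one place: 4-fluorophenyl in place of 5-hydroxy-2-nitrophenyl on a double-bonded chain carbon bound to a double-bonded chain carbon. The same place has been varied in every measured step of the series, and each of those steps stayed within the scatter: phenyl to 3,4-dimethoxyphenyl, phenyl to 5-hydroxy-2-nitrophenyl, and 3,4-dimethoxyphenyl to 5-hydroxy-2-nitrophenyl. Among the measured compounds shown here, no measured pair brings in a 4-fluorophenyl, so the closest point of reference is the plain phenyl of compound 1, which gave 25 ug/mL. On this basis, no step beyond the scatter is expected in this assay, with the number most likely near that of compound 1; the expected step is a 1.1-fold higher number from compound 3 to compound 4 (0.04 log units; within the scatter). Compound 4 is therefore estimated at 20 ug/mL, with a range from 8 ug/mL to 50 ug/mL.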

Compound 4, concentration for half-maximal effect: 3.96 ug/mL
For compound 4 the middle estimate is 5.1-fold (0.70 log units) above the measured one; the whole stated range lies above it.
By their numbers in this assay, from the lowest: compound 4; then compounds 2, 3 and 1 (each within the scatter of the next).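

In this assay, the position on the double-bonded chain carbon now shows a real response: fluoro in place of hydrogen on an aromatic carbon moves the number beyond the scatter (a 6.3-fold lower number from compound 1 to compound 4 (0.80 log units; beyond the scatter)), which no earlier change at this place did. The two more heavily substituted aryl groups show the same gap to 4-fluorophenyl (a 4.6-fold lower number from compound 3 to compound 4 (0.66 log units; beyond the scatter); a 3.3-fold lower number from compound 2 to compound 4 (0.51 log units; beyond the scatter)), leaving compound 4 alone at the low end of the four numbers, with an effect already at smaller amounts of compound. Among these compounds, the size of the step does not follow the size of the group exchanged: the single fluoro gives a step beyond the scatter from phenyl, whereas 3,4-dimethoxyphenyl and 5-hydroxy-2-nitrophenyl both stay within it.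

No measurement shown here accounts for the step. From the compounds shown here alone, whether chloro, methyl or an amine in the place of that fluoro would give a number like that of compound 4, and so whether the effect is specific to fluoro, remains open.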